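Hydroxy to methoxy on compound 1

A few compounds are considered here, and "the series" means these few. Any claim that something is new, unique, unknown or untested is made for them only; others in the source may bear on it.

In a functional assay on MDA-MB-435 cells (Homo sapiens) for antiproliferative activity, read by sulforhodamine B assay, with a stated time of 48 h (a lower number here means a stronger inhibitor of growth, a higher number a weaker inhibitor of growth), compound 1 `O=C(NCCCNc1cc(-c2cn(-c3ccccc3)nc2-c2cccc(O)c2)ccn1)Nc1ccc(F)cc1` gives 5050 nM and compound 2 `O=C(NCCCNc1cc(-c2cn(-c3ccccc3)nc2-c2cccc(O)c2)ccn1)Nc1cccc(C(F)(F)F)c1` gives 7570 nM so the two stand within the scatter of each other. Compound 3 `COc1cccc(-c2nn(-c3ccccc3)cc2-c2ccnc(NCCCNC(=O)Nc3ccc(F)cc3)c2)c1` differs from compound 1 by methyl in place of hydrogen on an oxygen on an aromatic ring which turns 3-hydroxyphenyl into 3-methoxyphenyl. Among the compounds with values here, the only measured step of a 1.5-fold higher number from compound 1 to compound 2 (0.18 log units; within the scatter) lies at another place, on an amide-type nitrogen, and no measured pair tests this change. No step beyond the scatter is therefore expected in this assay with only a slight lean towards a higher number. The expected step is a 1.4-fold higher number from compound 1 to compound 3 (0.14 log units; within the scatter) and no more. For compound 3 the estimated value is 7000 nM with a range from 2500 nM to 20000 nM in this estimate.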

Compound 3, concentration for total growth inhibition: 12800 nM
For compound 3 the middle estimate is 1.8-fold (0.26 log units) below the measured one, within the range that was stated.
By their numbers in this assay, from the lowest: compounds 1, 2 and 3 (each within the scatter of the next, the first and the last beyond it).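

Methyl in place of hydrogen on the oxygen, which turns 3-hydroxyphenyl into 3-methoxyphenyl, gives in this assay a 2.5-fold higher number from compound 1 to compound 3 (0.40 log units; beyond the scatter) while the only earlier step, on an amide-type nitrogen, stayed within the scatter. This position therefore responds to a change, if modestly, and the free hydroxy goes with the lower number in this pair. Nothing measured here accounts for the step. On these data alone, whether an amine or ethoxy in place of the hydroxy would hold or lose growth inhibition stays open. So does whether the same methyl would give a like step on compound 2.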